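A few compounds are considered here, and "the series" means these few. Any claim that something is new, unique, unknown or untested is made for them only; others in the source may bear on it.

Measured compounds:
Compound 1 `CC(O)(CSc1ccccc1)c1nc(-c2ccccc2)no1`: > 100000 nM
Compound 2 `CC(O)(CSc1ccc(Br)cc1)c1nc(-c2ccc([N+](=O)[O-])c(C(F)(F)F)c2)no1`: 1600 nM
Compound 3 `CC(O)(CSc1ccc(Br)cc1)c1nc(-c2ccccc2)no1`: > 100000 nM

In a functional assay on DU-145 cells (Homo sapiens) for cytotoxicity, read by MTT assay (on this read-out higher numbers stand for weaker inhibition and lower numbers for stronger inhibition), compound 2 gives 1600 nM. For compound 1 the value of > 100000 nM is a limit of this assay, not a number. For compound 3 the value of > 100000 nM is likewise a limit. Among the compounds with values here, compound 2 thus stands alone as the only number among the three, with the other two sitting at the limit of > 100000 nM in this assay, at which 2 of the 3 values shown sit. The step that the two limits leave unreadable from compound 1 to compound 3 is left unreadable by the two limits.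

Compound 4 `CC(O)(CS(=O)(=O)c1ccc(Br)cc1)c1nc(-c2ccc([N+](=O)[O-])c(C(F)(F)F)c2)no1` differs from compound 2 only as counted: (4-bromophenyl)sulfonyl in place of (4-bromophenyl)sulfanyl on a saturated chain carbon, two bonds along the chain from an aromatic carbon and an oxygen on a saturated carbon. No measured step among the three compounds touches this part of the chain, and the one step that is shown, from compound 1 to compound 3, concerns a different change and cannot be read. There is therefore nothing to set the size or direction of the step in this assay, and the expectation rests on compound 2 alone. The account expects compound 4 to stay within the scatter of compound 2, with a step of a 1.6-fold higher number from compound 2 to compound 4 (0.19 log units; within the scatter), and estimates for compound 4 a value of 2500 nM, in a range from 500 nM to 15000 nM.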

Compound 4, half-maximal inhibitory concentration: > 100000 nM
Compound 4: no number, only a limit; the forecaster's own chance of this, stated with the estimate: 15%; middle value at least 40-fold (1.60 log units) away from the limit.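

In this assay, within the data shown here, (4-bromophenyl)sulfonyl in place of (4-bromophenyl)sulfanyl on a saturated chain carbon, two bonds along the chain from an aromatic carbon and an oxygen on a saturated carbon, gives an at least 62-fold higher number from compound 2 to compound 4 (1.79 log units; beyond the scatter), the first readable step at this place and a large one. For compound 4 the value of > 100000 nM is a limit of this assay, not a number. The change thus shows that this part of the chain is not indifferent, and compound 2 now stands as the only compound with a number, the other three sharing one limit: the limit of > 100000 nM in this assay, at which 3 of the 4 values shown sit.

Going by these compounds, it remains open whether the drop belongs to the sulfonyl group itself or would also come with another link at this place, such as a sulfinyl group or an ether oxygen. Also open, on these data alone, is whether the same change would read alike with a chloro or a methoxy group in place of the bromo on the aromatic ring, and the limit leaves the full size of the step unknown.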